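Removing an Iodine From a Weak Antagonist Scaffold

The source may hold more compounds than are shown below. What is called first, only, known or untested is meant among the compounds shown, and "the series" means these compounds.

Two compounds share one core, a nitro-bearing ring fused to a benzene ring and carrying a trifluoromethyl group, and differ only in where an iodine sits on the benzene ring. Compound 1 `O=[N+]([O-])C1=Cc2cccc(I)c2OC1C(F)(F)F` and compound 2 `O=[N+]([O-])C1=Cc2cc(I)ccc2OC1C(F)(F)F` were both tested in an assay on 1321N1 cells for antagonist activity at P2Y purinoceptor 6 (Mus musculus), read by FLIPR and calcium flux; on this read-out lower numbers stand for stronger inhibition and higher numbers for weaker inhibition. In this assay compound 1 gives 17600 nM, and compound 2 gives 28700 nM. Compound 2 has the higher of the two numbers, but the gap to compound 1 falls within the scatter, so the two values cannot be told apart.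

Compound 3 `O=[N+]([O-])C1=Cc2ccccc2OC1C(F)(F)F` has not yet been measured. Compared with compound 2, it differs by hydrogen in place of iodo on an aromatic carbon. Within the data shown here, no measured pair shows what dropping a halogen does on this core, so any expectation rests only on the weak numbers of compound 1 and compound 2. Both sit in a region where the assay is close to its working limit. The estimate for compound 3 is a step of a 1.6-fold higher number from compound 2 to compound 3 (0.20 log units; within the scatter), a slight weakening but not clearly beyond the scatter. The expected value for compound 3 is 45000 nM, within a range from 12000 nM to 170000 nM.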

Compound 3, half-maximal inhibitory concentration: 185000 nM
Compound 3: the middle estimate sits 4.1-fold (0.61 log units) below what was measured; measured number outside the range, above it.
By their numbers in this assay, from the lowest: compounds 1 and 2 (each within the scatter of the next); then compound 3.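

In this assay, putting hydrogen in place of iodo on the aromatic carbon gives a 6.4-fold higher number from compound 2 to compound 3 (0.81 log units; beyond the scatter), and the same change from the other iodine placement gives an 11-fold higher number from compound 1 to compound 3 (1.02 log units; beyond the scatter), with both steps beyond the scatter. The comparison of compound 1 with compound 2 could not show this: their two iodine placements cannot be told apart, yet each gives stronger inhibition than compound 3, which has no iodine, so on this shared core an iodine at either of these two places matters far more than the choice between them. Nothing available here explains why the loss of this single heavy atom has such a large effect.

The compounds shown leave open whether iodine itself is required, or whether a smaller halogen such as bromine or chlorine, or a group such as methyl or nitrile, on the same aromatic carbon would keep the stronger inhibition. Also open, as far as these compounds go, is whether an iodine on another aromatic carbon of the core, or iodines at both places seen in compound 1 and compound 2 together, would improve on those two compounds.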